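Swapping the amide amine for methylpiperazine: clearance outlook

This account rests on a few compounds, and the source may have more. Where it says the series, first, only, none or still open, it means among the compounds named here.

Measured compounds, in an ADME assay on microsomes from liver (Homo sapiens) for metabolic stability, read by LC-MS, using NADPH, with a stated time of 45 min, tested at 0.5 uM; a lower number here means slower removal, a higher number faster removal of the compound:
Compound 1 `O=C(CCSc1nc2cc(Cl)ccc2o1)N1CCCCC1` gives 10.7 mL/min/g.
Compound 2 `CCN(CC)C(=O)CCSc1nc2cc(Cl)ccc2o1` gives 5.9 mL/min/g.

Among the measured compounds shown here, compound 2 has the lowest of the two numbers in this assay, but its only neighbour, compound 1, stands a step away that is a 1.8-fold lower number from compound 1 to compound 2 (0.26 log units; within the scatter), so the two cannot be told apart. Compound 3 `CN1CCN(C(=O)CCSc2nc3cc(Cl)ccc3o2)CC1` is not yet measured; it differs from compound 2 by 4-methylpiperazin-1-yl in place of diethylamino on a carbonyl carbon. For the measured compounds named here, the one measured step, a 1.8-fold lower number from compound 1 to compound 2 (0.26 log units; within the scatter), also exchanged only the group on the carbonyl carbon and stayed within the scatter, so such an exchange has so far produced no shift that can be trusted. For compound 3 in this assay no step beyond the scatter is therefore expected, and the estimated step of a 1.1-fold lower number from compound 2 to compound 3 (0.03 log units; within the scatter) is small. Compound 3 is estimated at 5.5 mL/min/g, with a range from 2.5 mL/min/g to 12 mL/min/g.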

Compound 3, intrinsic clearance in a liver preparation (reported as CLH), per the amount of preparation that the assay uses: 1.5 mL/min/g
Compound 3: middle estimate off by 3.7-fold (0.56 log units), on the high side, and the stated range ends above it.
By their numbers in this assay, from the lowest: compound 3; then compounds 2 and 1 (each within the scatter of the next).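

The group on the carbonyl carbon can clearly move the number in this assay after all. With 4-methylpiperazin-1-yl entering, there is a 3.9-fold lower number from compound 2 to compound 3 (0.59 log units; beyond the scatter) against diethylamino and a 7.1-fold lower number from compound 1 to compound 3 (0.85 log units; beyond the scatter) against piperidin-1-yl, and both steps lie beyond the scatter, which the earlier exchange between those two groups did not reach. Nothing available here explains why the number falls.

Still open is which part of the entering group carries the step, since the ring's second nitrogen and its methyl arrive together in compound 3 and the compounds shown cannot separate them. A piperazin-1-yl group without the methyl, or a morpholin-4-yl group on the same carbonyl carbon, would help to tell these two parts apart.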